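Swapping a Thiophene Ring for a Methoxyphenoxy Group

The source may report more compounds than this note shows. Statements on the series, on what has been measured and on what is new or still open speak of the compounds shown alone.

Of the compounds shown here, three sharing one core have been measured in an assay on isolated protein for agonist activity at Bile acid receptor (Homo sapiens), read by AlphaScreen, with a stated time of 30 min; a higher number here means a larger maximal response, a lower number a smaller maximal response. Compound 1 `COc1ccc(C2SC(C)C(=O)Nc3c2c(C)nn3-c2ccccc2C)c(OC)c1` gives 63%. Compound 2 `Cc1nn(-c2ccccc2I)c2c1C(c1ccc(Oc3ccccc3)cc1)SC(C)C(=O)N2` gives 130%, the highest of the three. Compound 3 `Cc1ccccc1-n1nc(C)c2c1NC(=O)[C@H](C)S[C@@H]2c1ccc(-c2ccsc2)cc1` gives 68%, which places it second of the three numbers: its nearest neighbour is compound 1, whose value lies within the usual scatter, while compound 2 stands far beyond the scatter above it.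

Compound 4 `COc1ccccc1Oc1ccc([C@H]2S[C@@H](C)C(=O)Nc3c2c(C)nn3-c2ccccc2C)cc1` has not yet been measured. It differs from compound 3 in one place: 2-methoxyphenoxy in place of thiophen-3-yl on an aromatic carbon. For the measured compounds named here, no single-change step between two measured compounds is available to calibrate this swap, so the expectation rests on the three values alone. Compound 2 also carries an aromatic ring linked through oxygen on the same part of the molecule, and its high maximal response suggests that an oxygen-linked aromatic ring can be tolerated well, though compound 2 differs from compound 4 elsewhere too, so the comparison is loose.

For compound 4, a moderate upward step a number 27 percentage points higher from compound 3 to compound 4 (beyond the scatter) is expected, because compound 2 gives 130%. Compound 4 is therefore estimated at 95%, with a likely range from 60% to 135%.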

Compound 4, largest response reached (reported as efficacy), in percent of the reference or control that the assay uses: 240%
Beside the measured number, compound 4's estimate is 145 percentage points below it; measured number outside the range, above it.
By their numbers in this assay, from the lowest: compounds 1 and 3 (each within the scatter of the next); then compound 2; then compound 4.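

In this assay, replacing thiophen-3-yl with 2-methoxyphenoxy gives a number 172 percentage points higher from compound 3 to compound 4 (beyond the scatter), a large step. For the compounds shown here, this is the first pair that differs in one place only, and it shows that this aromatic carbon, para to a large group, is a position where a single change can strongly alter the maximal response on the shared core. The step comes with a swap of a five-membered aromatic ring containing sulfur for a six-membered aromatic ring of carbon only, carrying a methoxy group and joined through oxygen, but nothing measured here bears on the reason for it.

Several features change together in this swap, so the single step cannot say whether the linking oxygen, the six-membered ring or the methoxy group accounts for the rise. From the compounds shown here alone, a comparison with a 2-chlorophenoxy group, or with a phenylamino group that has nitrogen as the link in place of oxygen, would help to separate these features, and how far the rise carries over to other groups elsewhere on the core remains open.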